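The source may report more compounds than this note shows. Statements on the series, on what has been measured and on what is new or still open speak of the compounds shown alone.

Among the measured compounds shown here, compound 3, `Cc1cc(N2CC[C@@H](C)[C@@H](N(C)c3ncnc4[nH]ccc34)C2)n2nc(SCc3ccc(F)c(Cl)c3)nc2n1`, gives 98900 nM in a functional assay on BGC-823 cells (Homo sapiens) for inhibition, read by MTT assay, with a stated time of 72 h (on this read-out lower numbers stand for stronger inhibition and higher numbers for weaker inhibition), the highest of the three numbers known. Compound 1, `CCCSc1nc2nc(C)cc(N3CC[C@@H](C)[C@@H](N(C)c4ncnc5[nH]ccc45)C3)n2n1`, gives 51200 nM, and compound 2, `C=CCSc1nc2nc(C)cc(N3CC[C@@H](C)[C@@H](N(C)c4ncnc5[nH]ccc45)C3)n2n1`, gives 40900 nM. Both steps that reach compound 3, a 1.9-fold higher number from compound 1 to compound 3 (0.29 log units; within the scatter) and a 2.4-fold higher number from compound 2 to compound 3 (0.38 log units; beyond the scatter), change the group on the saturated chain carbon bound to a sulfur, as does a 1.3-fold lower number from compound 1 to compound 2 (0.10 log units; within the scatter). Compound 4, `Cc1cc(N2CC[C@@H](C)[C@@H](N(C)c3ncnc4[nH]ccc34)C2)n2nc(SCc3ccc(F)cc3)nc2n1`, differs from compound 3 by hydrogen in place of chloro on an aromatic carbon. For the measured compounds named here, no measured step touches a substituent on that aromatic ring, so the known steps bear on it only in showing that the groups on the sulfur-bound carbon alter the read-out by little. Compound 4 is therefore expected to stay near compound 3, with a 1.4-fold lower number from compound 3 to compound 4 (0.15 log units; within the scatter), and is estimated at 70000 nM with a range of 30000 nM to 160000 nM.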

Compound 4, half-maximal inhibitory concentration: 44300 nM
The estimate for compound 4 lay 1.6-fold (0.20 log units) above the measured number, within the range that was stated.
By their numbers in this assay, from the lowest: compounds 2, 4, 1 and 3 (each within the scatter of the next, the first and the last beyond it).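

Among the compounds shown here, replacing chloro with hydrogen is the first measured change on the aromatic ring itself, and in this assay it gives a 2.2-fold lower number from compound 3 to compound 4 (0.35 log units; beyond the scatter), a modest step beyond the scatter. The resulting 4-fluorophenyl group reads within the scatter of both vinyl and ethyl on the sulfur-bound carbon, with a 1.1-fold higher number from compound 2 to compound 4 (0.03 log units; within the scatter) and a 1.2-fold lower number from compound 1 to compound 4 (0.06 log units; within the scatter). Nothing available explains the effect of removing the chloro. The compounds shown leave open how a bromo or methoxy group in place of that chloro would read, and what hydrogen in place of the fluoro group would do.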